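Moving a hydroxyl group on a pyridine-based topoisomerase inhibitor

The compounds below may be only part of what the source reports. "The series", "measured", "known", "first", "only" and "open" are said of these compounds alone.

Three compounds share a core carrying two hydroxyphenyl groups and one five-membered ring. Compound 1 `Oc1ccc(-c2cc(-c3cccs3)cc(-c3ccccc3O)n2)cc1` gives 72.2% in an assay on isolated protein for inhibition of DNA topoisomerase 1 (Homo sapiens), with a stated time of 30 min, tested at 100 uM; on this read-out lower numbers stand for a weaker effect and higher numbers for a stronger effect at the one concentration tested. Compound 2 `Oc1ccc(-c2cc(-c3ccco3)cc(-c3ccc(O)cc3)n2)cc1` gives 100% in this assay, and compound 3 `Oc1ccc(-c2cc(-c3ccoc3)cc(-c3ccccc3O)n2)cc1` gives 30.1%, the lowest of the three, since compound 1 and compound 2 both sit beyond the scatter above it. Within the data shown here, the one single-change step known, a number 42.1 percentage points lower from compound 1 to compound 3 (beyond the scatter), concerns the five-membered ring rather than the hydroxyphenyl groups. Compound 4 `Oc1ccc(-c2cc(-c3ccoc3)cc(-c3ccc(O)cc3)n2)cc1` differs from compound 3 only in this way: 4-hydroxyphenyl in place of 2-hydroxyphenyl on an aromatic carbon. Among the measured compounds shown here, no measured step covers this change, so the expectation is uncertain; compound 2, which also carries two 4-hydroxyphenyl groups, gives the highest value seen, but it differs from compound 4 in its five-membered ring too. Compound 4 is expected to show a number 29.9 percentage points higher from compound 3 to compound 4 (beyond the scatter), giving an estimated 60%, between 30% and 95%.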

Compound 4, a percentage reported as inhibition, at one concentration (the size of the read-out at that concentration, not a potency): 74.9%
Compound 4: the middle estimate sits 14.9 percentage points below what was measured, and the stated range covers the measured number.
By their numbers in this assay, from the lowest: compound 3; then compounds 1 and 4 (each within the scatter of the next); then compound 2.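

In this assay, swapping 2-hydroxyphenyl for 4-hydroxyphenyl next to the ring nitrogen, with the same atoms overall, produces a large step (a number 44.8 percentage points higher from compound 3 to compound 4 (beyond the scatter)), so the location of the hydroxyl on this group matters. The five-membered ring still counts once 4-hydroxyphenyl is in place, as furan-3-yl in place of furan-2-yl gives a modest step (a number 25.1 percentage points lower from compound 2 to compound 4 (beyond the scatter)). Nothing available explains either change.

As far as these compounds go, whether the same swap gives a similar step alongside thiophen-2-yl remains open. So does whether an amine or a carboxylic acid in place of the hydroxyl would keep the value.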